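Replacing oxolan-2-yl with 1-(hydroxymethyl)ethyl in compound 4

This account rests on a few compounds, and the source may have more. Where it says the series, first, only, none or still open, it means among the compounds named here.

Compound 2 `Cc1cc(C)c(CN2CCc3c(Cl)cc([C@@H](CO)[C@@H]4CCCO4)c(Cl)c3C2=O)c(=O)[nH]1` belongs to a small group of compounds built on one shared core. In a functional assay on KARPAS-422 cells (Homo sapiens) for antiproliferative activity, read by resazurin assay, with a stated time of 72 h (on this read-out lower numbers stand for stronger inhibition and higher numbers for weaker inhibition), compound 2 gives 1220 nM, the lowest of the two single numbers obtained so far. Going by the values given here, its nearest neighbour, compound 1 `Cc1cc(C)c(CN2CCc3c(Cl)cc([C@@H](CO)[C@@H]4CCOC4)c(Cl)c3C2=O)c(=O)[nH]1`, gives 3950 nM, and the only one-place step measured to date is a 3.2-fold lower number from compound 1 to compound 2 (0.51 log units; beyond the scatter). Compound 3 `COC(c1cc(Cl)c2c(c1Cl)C(=O)N(Cc1c(C)cc(C)[nH]c1=O)CC2)C1CCOCC1` has been run twice in this assay, where compound 3 gives 1150 nM; 19 nM (2 entries); the spread recorded in the several entries of compound 3 in this assay, 1150 nM; 19 nM (2 entries) shows how far repeated readings of a single compound can lie apart.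

Compound 4 `Cc1cc(C)c(CN2CCc3c(Cl)cc([C@@H](C)CO)c(Cl)c3C2=O)c(=O)[nH]1` has not yet been measured. The change from compound 2 is a group of 4 heavy atoms (3 carbon, 1 oxygen; no ring) in place of a group of 8 heavy atoms (6 carbon, 2 oxygen; one five-membered non-aromatic ring with 1 hetero atom), on an aromatic carbon. Among the compounds with values here, no measured step removes this five-membered ring altogether; the closest guide is a 3.2-fold lower number from compound 1 to compound 2 (0.51 log units; beyond the scatter), which shows that altering where the ring is attached already moves the number beyond the scatter. Removing the ring entirely is a bigger change, so compound 4 is expected to give a higher number than compound 2, a step of a 3.3-fold higher number from compound 2 to compound 4 (0.52 log units; beyond the scatter). The estimate for compound 4 is 4000 nM, with a likely range from 1000 nM to 16000 nM.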

Compound 4, half-maximal inhibitory concentration: 1500 nM
Beside the measured number, compound 4's estimate is 2.7-fold (0.43 log units) above it, within the range that was stated.
By their numbers in this assay, from the lowest: compounds 2 and 4 (each within the scatter of the next); then compound 1.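

Swapping the ring-bearing group for the smaller open chain, 1-(hydroxymethyl)ethyl, on this aromatic carbon leaves the antiproliferative reading in this assay essentially in place, with a 1.2-fold higher number from compound 2 to compound 4 (0.09 log units; within the scatter), so the five-membered ring with its oxygen is not required for this level of activity. The same open chain also compares favourably with the oxolan-3-yl version, with a 2.6-fold lower number from compound 1 to compound 4 (0.42 log units; beyond the scatter), which shows that the oxolan-3-yl arrangement reads worse than the open chain, whereas the oxolan-2-yl arrangement cannot be told apart from it. Even so, the step beyond the scatter deserves caution, because a single compound has given readings very far apart in this assay: the several entries of compound 3 in this assay, 1150 nM; 19 nM (2 entries)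

Going by these compounds, compounds 1, 2 and 4 all keep a hydroxymethyl group at this place, so it remains open whether a chain ending in an amine or a carboxylic acid, or a longer chain, would read the same. The compounds shown also leave open whether the opposite arrangement at the defined stereocentre of the 1-(hydroxymethyl)ethyl group would change the reading.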